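Cyclopropyloxycarbonyl to 2-methyl-2H-tetrazol-5-yl on the shared core

A few compounds are considered here, and "the series" means these few. Any claim that something is new, unique, unknown or untested is made for them only; others in the source may bear on it.

Within the data shown here, compound 2 `CCc1nc(NN2C(=O)C=C(C)C2=O)ncc1C(=O)OC1CC1` holds the lower of the two numbers measured so far: in a functional assay on Jurkat cells (Homo sapiens) for inhibition (on this read-out lower numbers stand for stronger inhibition and higher numbers for weaker inhibition), compound 2 gives 120 nM, while compound 1 `CC(=O)c1cnc(NN2C(=O)C=C(C)C2=O)nc1C(F)(F)F` gives 4400 nM, a gap that lies beyond the scatter. Compound 3 `CCc1nc(NN2C(=O)C=C(C)C2=O)ncc1-c1nnn(C)n1` is the next variation on compound 2: 2-methyl-2H-tetrazol-5-yl in place of cyclopropyloxycarbonyl on an aromatic carbon. Among the measured compounds shown here, no measured pair shows this exchange, so the step itself is untested. A modest weakening is expected, a 1.8-fold higher number from compound 2 to compound 3 (0.26 log units; within the scatter), resting only on compound 2 at 120 nM in this assay. Compound 3 is estimated at 220 nM, within 60 nM to 800 nM.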

Compound 3, half-maximal inhibitory concentration: 10000 nM
For compound 3 the middle estimate is 45-fold (1.66 log units) below the measured one, and the stated range ends below it.
By their numbers in this assay, from the lowest: compound 2; then compound 1; then compound 3.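

In this assay, replacing cyclopropyloxycarbonyl with 2-methyl-2H-tetrazol-5-yl on the aromatic carbon ortho to an ethyl group gives an 83-fold higher number from compound 2 to compound 3 (1.92 log units; beyond the scatter). This position therefore does not accept every group of 6 heavy atoms, and the step is large even though the count is unchanged. Nothing available explains the loss. The compounds shown leave open whether the loss comes from losing cyclopropyloxycarbonyl or from gaining the tetrazolyl ring. Also open, as far as these compounds go, is how a methoxycarbonyl group or a carboxylic acid would fare here with the ethyl group kept.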